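A few compounds are considered here, and "the series" means these few. Any claim that something is new, unique, unknown or untested is made for them only; others in the source may bear on it.

In an ADME assay on microsomes from liver (Homo sapiens) for metabolic stability, read by LC-MS, with a stated time of 30 min, tested at 1 uM (on this read-out lower numbers stand for a less stable compound and higher numbers for a more stable compound), compound 1 `O=C(NCc1ccc(S(=O)(=O)c2ccccc2C(F)(F)F)cc1)c1cc2cnccc2[nH]1` gives 52%. Compound 2 `O=C(NCc1ccc(S(=O)(=O)N2CCCCC2)cc1)c1cc2ccncc2o1` gives 56% and compound 3 `O=C(NCc1ccc(S(=O)(=O)N2CCCCC2)cc1)c1ccc2nc[nH]c2c1` gives 53%, so the number for compound 1 lies within the usual scatter of both. Among the compounds with values here, the only measured step, a number 3 percentage points lower from compound 2 to compound 3 (within the scatter), exchanges the shared core on the carbonyl carbon and leaves the read-out unchanged. Compound 4 `O=C(NCc1ccc(S(=O)(=O)c2ccccc2)cc1)c1cc2cnccc2[nH]1` differs from compound 1 by hydrogen in place of trifluoromethyl on an aromatic carbon. Within the data shown here, no measured step touches this position, so nothing in the data points in either direction. Because a number 3 percentage points lower from compound 2 to compound 3 (within the scatter) was within the scatter and the three numbers sit close, the estimated step of no change at the digits printed from compound 1 to compound 4 (within the scatter) is expected to stay within the scatter. Compound 4 is therefore estimated at 52%, with a range from 35% to 68%.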

Compound 4, percent of the compound remaining: 75%
The estimate for compound 4 lay 23 percentage points below the measured number; the measured number lies above the stated range.
By their numbers in this assay, from the lowest: compounds 1, 3 and 2 (each within the scatter of the next); then compound 4.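

In this assay the change from 2-(trifluoromethyl)phenyl to phenyl gives a number 23 percentage points higher from compound 1 to compound 4 (beyond the scatter) and is the only step shown that lies beyond the scatter. The read-out therefore responds to what stands at this place, on an aromatic carbon ortho to a large group, unlike the exchange on the carbonyl carbon in a number 3 percentage points lower from compound 2 to compound 3 (within the scatter). Nothing at hand explains this step. On these data alone, whether fluorine, chlorine or a methyl group at this place would read like hydrogen or like trifluoromethyl stays open. So does whether the step would hold with a different group on the carbonyl carbon.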